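Series notes: swapping the aryl end of compound 1

The source may report more compounds than this note shows. Statements on the series, on what has been measured and on what is new or still open speak of the compounds shown alone.

For the measured compounds named here, compound 1 `Cc1ccc2c(c1)/C(=N/NC(=S)N/N=C/c1ccccn1)C(=O)N2` is the only member of the set that returns a number in a functional assay on COS-7 cells (Chlorocebus aethiops) for inhibition, read by MTT assay; on this read-out higher numbers stand for weaker inhibition and lower numbers for stronger inhibition; in this assay compound 1 gives 2120 nM. Compound 2 `COc1ccc(/C=N/NC(=S)N/N=C2\C(=O)Nc3ccc(C)cc32)c(OC)c1` reaches only a limit in this assay, where compound 2 gives > 50000 nM. Compound 3 `O=C1Nc2ccc(Br)cc2/C1=N/NC(=S)N/N=C/c1ccc(-c2ccccc2)cc1` likewise ends at a limit in this assay, compound 3 giving > 50000 nM. Going by the values given here, compound 1 therefore stands at the one measured value, while the rest of the set sits at the limit of > 50000 nM in this assay, at which 2 of the 3 values shown sit. Among the compounds with values here, no two measured compounds differ in a single place, so no measured step is available.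

Compound 4 `Cc1ccc2c(c1)/C(=N/NC(=S)N/N=C/c1ccc(Br)cc1)C(=O)N2` differs from compound 1 in one place: 4-bromophenyl in place of pyridin-2-yl on a carbon with a double bond to nitrogen. The change removes the only ring bearing a hetero atom at that carbon. With no measured step of this kind in this assay, the expectation leans toward weaker inhibition because two of the three values already sit at the limit of > 50000 nM in this assay, at which 2 of the 3 values shown sit. The step from compound 1 to compound 4 is expected to be a 7.1-fold higher number from compound 1 to compound 4 (0.85 log units; beyond the scatter), beyond the scatter and in the direction of weaker inhibition. Compound 4 is estimated at 15000 nM in this assay, within 3000 nM to 50000 nM, with a real chance that only a limit is reported.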

Compound 4, half-maximal inhibitory concentration: > 50000 nM
Compound 4 ended at the assay's limit; the forecaster's own chance of this, stated with the estimate: 40%; middle value at least 3.3-fold (0.52 log units) from the limit.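

For the compounds shown here, compound 4 gives the first single-place comparison in this assay: 4-bromophenyl in place of pyridin-2-yl on a carbon with a double bond to nitrogen is an at least 23-fold higher number from compound 1 to compound 4 (1.37 log units; beyond the scatter), a large step that lies beyond the scatter. Compound 4 gives > 50000 nM, which is a limit and not a number, so the step has a floor but no known size. The change shows that inhibition at this position does not survive this replacement, which takes out a ring with one hetero atom and one hydrogen-bond acceptor and brings in a carbon-only ring with bromine, and pyridin-2-yl remains the only end group here with a measured number: the limit of > 50000 nM in this assay, at which 3 of the 4 values shown sit.

The compounds shown leave open whether the loss follows the departure of the ring nitrogen or the arrival of the bromine, since both happen in this one change, and a plain phenyl at that carbon would separate the two. Also open, as far as these compounds go, is whether the ring nitrogen must sit as it does in pyridin-2-yl, which a pyridin-3-yl or pyridin-4-yl in this assay would test.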